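The source may hold more compounds than are shown below. What is called first, only, known or untested is meant among the compounds shown, and "the series" means these compounds.

Measured in a functional assay on CWR22R cells (Homo sapiens) for antiproliferative activity, read by CCK-8 assay, with a stated time of 6 days; a lower number here means a stronger inhibitor, a higher number a weaker inhibitor:
- compound 1 `CCN(c1ccc(C#N)c(Cl)c1)c1cc(-n2cnc3ccccc32)ccc1C`: 3040 nM
- compound 2 `CCN(c1ccc(C#N)c(Cl)c1)c1cc(-c2ccco2)ccc1C`: > 30000 nM

Compound 2 gives > 30000 nM, which is a limit of the assay and not a number. Its true position is therefore open on the weak side of the scale.

Compound 3 `CCN(c1ccc(C#N)c(Cl)c1)c1cc(-c2cncnc2)ccc1C` carries pyrimidin-5-yl in place of furan-2-yl on an aromatic carbon, meta to a large group and para to a methyl group: pyrimidin-5-yl in place of furan-2-yl on an aromatic carbon.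

Among the measured compounds shown here, only one measured step bears on this place: an at least 9.8-fold higher number from compound 1 to compound 2 (0.99 log units; beyond the scatter), which lies beyond the scatter and replaces 1H-benzimidazol-1-yl with furan-2-yl. It shows that the group here matters in this assay, but one step gives no rule for pyrimidin-5-yl. With compound 1 at 3040 nM as the only numerical reference, a move towards a lower number is expected, probably smaller than that step. Compound 3 may well stay at the limit of the assay.

The expected change is an at least 2.5-fold lower number from compound 2 to compound 3 (0.39 log units; beyond the scatter). The estimated value for compound 3 is 12000 nM, with an expected range of 3500 nM to 30000 nM.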

Compound 3, half-maximal inhibitory concentration: > 30000 nM
Compound 3 was reported as a limit; the forecaster's own chance of this, stated with the estimate: 35%; at least 2.5-fold (0.39 log units) between middle value and limit.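

In this assay compound 3 gives > 30000 nM, which is a limit of the assay and not a number. Pyrimidin-5-yl in place of 1H-benzimidazol-1-yl gives an at least 9.8-fold higher number from compound 1 to compound 3 (0.99 log units; beyond the scatter), so a six-membered aromatic ring with 2 hetero atoms joins the five-membered furan-2-yl at this place, meta to a large group and para to a methyl group, and among the three groups shown only 1H-benzimidazol-1-yl gives a measurable number. No order can be drawn between furan-2-yl and pyrimidin-5-yl, and the step between them cannot be read, because both compounds sit at the same limit: the limit of > 30000 nM in this assay, at which 2 of the 3 values shown sit.

The compounds shown leave open whether the value of compound 1 depends on the link through ring nitrogen, on the fused benzene ring, or on both, since 1H-benzimidazol-1-yl differs from the other two groups in more than one respect. As far as these compounds go, a smaller nitrogen-linked ring such as 1H-imidazol-1-yl, or an indol-1-yl group, would separate these features, and the response of this place to an amine or a carboxylic acid also remains open.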